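The compounds below may be only part of what the source reports. "The series", "measured", "known", "first", "only" and "open" are said of these compounds alone.

Compound 1 `COc1ccc(-n2cc(CSC(=S)N3CCN(C(=O)OC(C)(C)C)CC3)nn2)cc1` gives in a functional assay on ECa-109 cells (Homo sapiens) for inhibition, read by MTT assay, with a stated time of 72 h (a higher number here means a weaker inhibitor, a lower number a stronger inhibitor), only the limit > 128000 nM and no number. Compound 2 `Fc1ccc(Cn2cc(CSC(=S)N3CCNCC3)nn2)cc1` likewise sits at the limit > 128000 nM in this assay. Compound 3 `S=C(SCc1cn(Cc2ccccc2Cl)nn1)N1CCNCC1` also sits at the limit > 128000 nM there. Among the compounds with values here, the one single-point step measured, a step that the two limits leave unreadable from compound 2 to compound 3, is accordingly unreadable. Compound 4 `CC(C)(C)OC(=O)N1CCN(C(=S)SCc2cn(Cc3ccc(Cl)cc3)nn2)CC1` differs from compound 1 by 4-chlorobenzyl in place of 4-methoxyphenyl on an aromatic nitrogen. Within the data shown here, no measured step bears directly on this change; all that is known of the series is the limit of > 128000 nM in this assay, at which 3 of the 3 values shown sit, so no step beyond the scatter is expected in this assay and a further limit is the likeliest outcome. Compound 4 is therefore expected at 150000 nM, between 60000 nM and 400000 nM. The step this estimate implies, a step that the limit leaves unreadable from compound 1 to compound 4, is an expectation only.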

Compound 4, half-maximal inhibitory concentration: > 128000 nM
Compound 4 ended at the assay's limit (the forecaster's own chance of this, stated with the estimate: 75%); the middle value lies beyond the limit too.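

With compound 1 and compound 4 both given only as limits in this assay, no step can be read between them. Still open is which change to the shared core, if any, would give a measurable value: the limit of > 128000 nM in this assay, at which 4 of the 4 values shown sit.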